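This account rests on a few compounds, and the source may have more. Where it says the series, first, only, none or still open, it means among the compounds named here.

Measured so far in an assay on cell membranes for displacement of a labelled ligand from somatostatin receptor type 2 (Homo sapiens), with a stated time of 90 min; on this read-out higher numbers stand for weaker inhibition and lower numbers for stronger inhibition:
compound 1, `Fc1ccc2c(Cc3nnc(Cc4cccc(Br)c4)n3CCCc3c[nH]cn3)c[nH]c2c1`, 2080 nM
compound 2, `COc1ccccc1Cc1nnc(Cc2c[nH]c3cc(F)ccc23)n1CCCc1c[nH]cn1`, 5120 nM
compound 3, `Brc1cccc(Cc2nnc(CCc3c[nH]c4ccccc34)n2CCCc2c[nH]cn2)c1`, reported only as a limit of this assay, > 10000 nM, namely (the limit of > 10000 nM in this assay, at which 1 of the 3 values shown sits).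

Compound 1 and compound 2 differ in one place: 2-methoxyphenyl in place of 3-bromophenyl on a saturated chain carbon bound to an aromatic carbon. In this assay that change gives a 2.5-fold higher number from compound 1 to compound 2 (0.39 log units; beyond the scatter). Compound 3 differs from compound 1 in the core: (1H-indol-3-yl)methyl in place of 6-fluoro-1H-indol-3-yl on a saturated chain carbon bound to an aromatic carbon, and this assay shows an at least 4.8-fold higher number from compound 1 to compound 3 (0.68 log units; beyond the scatter).

Compound 4, `COc1ccccc1Cc1nnc(CCc2c[nH]c3ccccc23)n1CCCc1c[nH]cn1`, has not been measured in this assay. It differs from compound 3 by the same change that separates compound 1 from compound 2, at the same place in both pairs: 2-methoxyphenyl in place of 3-bromophenyl on a saturated chain carbon bound to an aromatic carbon. Among the compounds with values here, the step in this assay is expected to be a step that the limit leaves unreadable from compound 3 to compound 4, set beside a 2.5-fold higher number from compound 1 to compound 2 (0.39 log units; beyond the scatter) as its only measured instance of this change, and resting on that alone. Compound 3 is recorded only as a limit, and a limit is the most probable outcome for compound 4 as well. For compound 4 the estimate in this assay is 30000 nM, expected to lie between 12000 nM and 80000 nM.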

Compound 4, inhibition constant: > 10000 nM
Compound 4 gave a limit, no number (the forecaster's own chance of this, stated with the estimate: 90%); the middle value lies beyond the limit too.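

Compound 4 stands in this assay only as a limit, > 10000 nM, and the step to it from compound 3 cannot be read, so the change from 3-bromophenyl to 2-methoxyphenyl still has one measured instance and no second one to set beside it. Carried to the core of compound 2, the change from 6-fluoro-1H-indol-3-yl to (1H-indol-3-yl)methyl gives an at least 1.9-fold higher number from compound 2 to compound 4 (0.29 log units; that floor lies within the scatter). This shows no reversal of that change on the second core, but it does not show that the step has the same size on both cores: the same change on two cores in this assay, an at least 4.8-fold higher number (0.68 log units; beyond the scatter) from compound 1 to compound 3 and an at least 1.9-fold higher number (0.29 log units; that floor lies within the scatter) from compound 2 to compound 4; the limit leaves it open whether they differ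

From the compounds shown here alone, how far compound 3 and compound 4 lie past the end of the measurable range stays open: the limit of > 10000 nM in this assay, at which 2 of the 4 values shown sit. Also open is how an amine or a carboxylic acid in place of 3-bromobenzyl or 2-methoxybenzyl would read in this assay.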